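Two Methyl Placements on a Shared Core

This account rests on a few compounds, and the source may have more. Where it says the series, first, only, none or still open, it means among the compounds named here.

This series rests on one shared core that carries a hydroxyl group and a naphthalene ring, and differs in where methyl groups sit on the core. Compound 1 `Oc1cc(-c2ccc3ccccc3c2)nc2ncccc12` is the unmethylated member with the naphthalene attached through one of its carbons. In a functional assay on SK-MEL-5 cells (Homo sapiens) for antiproliferative activity (on this read-out higher numbers stand for weaker inhibition of growth and lower numbers for stronger inhibition of growth), compound 1 gives 3470 nM. Compound 2 `Cc1ccnc2nc(-c3cccc4ccccc34)cc(O)c12` carries one methyl on the core and the naphthalene attached through a different carbon; how the two cores differ is not broken down here. In this assay compound 2 reaches only a limit, < 10 nM, as noted in the limit of < 10 nM in this assay, at which 1 of the 3 values shown sits. Compound 3 `Cc1cc(C)c2c(O)cc(-c3cccc4ccccc34)nc2n1` adds a second methyl to compound 2, the change being (methyl in place of hydrogen on an aromatic carbon), and in this assay compound 3 gives 468 nM. That single addition brings an at least 46-fold higher number from compound 2 to compound 3 (1.67 log units; beyond the scatter).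

Compound 4 `Cc1ccnc2nc(-c3ccc4ccccc4c3)cc(O)c12` is the unmeasured member: compound 1 with a methyl added, a change counted as methyl in place of hydrogen on an aromatic carbon. It is the same kind of change as from compound 2 to compound 3, but not the same, since here the methyl sits opposite the ring nitrogen and ortho to a fused ring, while there it sat next to the ring nitrogen. Compound 2, which carries a methyl at this very place, reaches the limit already given, so a gain rather than the loss seen from compound 2 to compound 3 seems more likely. Compound 4 is expected to give about 800 nM, from 120 nM to 5000 nM. That estimate means a 4.3-fold lower number from compound 1 to compound 4 (0.64 log units; beyond the scatter), a step that is expected but uncertain, since the naphthalene attachment in compound 4 matches compound 1 and not compound 2.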

Compound 4, concentration for 50% growth inhibition: 437 nM
Beside the measured number, compound 4's estimate is 1.8-fold (0.26 log units) above it; measured number inside the range.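

In this assay, a methyl in place of hydrogen on an aromatic carbon gives a 7.9-fold lower number from compound 1 to compound 4 (0.90 log units; beyond the scatter), so on the core of compound 1 the added methyl goes with stronger inhibition of growth. The change that carries the same description runs the opposite way on the other core, so neither its size nor its direction carries over between these two cores: the same change on two cores in this assay, an at least 46-fold higher number (1.67 log units; beyond the scatter) from compound 2 to compound 3 and a 7.9-fold lower number (0.90 log units; beyond the scatter) from compound 1 to compound 4, at least 370-fold (2.57 log units) apart, beyond the scatter of two such steps. What this does not show is why the two steps part ways, as the methyl does not sit at the same place in both and the two cores also differ in how the naphthalene is attached, and the value of compound 2 is only a limit: the limit of < 10 nM in this assay, at which 1 of the 4 values shown sits.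

With only two such steps, the compounds shown leave open how a methyl would behave at this place on further cores, and whether adding a second methyl to compound 4 would repeat the rise in number seen on the other core. Also open, as far as these compounds go, is whether a group other than methyl on this aromatic carbon, such as an amine, a carboxylic acid or a longer chain, would follow the same course.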